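Amide for hydroxypropyl on a piperidine: metabolic stability

The compounds below may be only part of what the source reports. "The series", "measured", "known", "first", "only" and "open" are said of these compounds alone.

Measured compounds:
Compound 1 `OC(Cc1ccccc1)CN1CCC(NCCSC(c2ccc(F)cc2)c2ccc(F)cc2)CC1`: 100%
Compound 2 `[O-][S+](CCNC1CCN(CC(O)Cc2ccccc2)CC1)C(c1ccc(F)cc1)c1ccc(F)cc1`: 100%
Compound 3 `O=C(c1ccc(F)cc1)N1CCC(NCCSC(c2ccc(F)cc2)c2ccc(F)cc2)CC1`: 100%

Of the compounds shown here, three have been tested in an ADME assay on microsomes from liver (Rattus norvegicus) for metabolic stability, read by LC-MS, using NADPH, tested at 10 uM; on this read-out higher numbers stand for a more stable compound and lower numbers for a less stable compound. Compound 1 gives 100%, and compound 3 gives 100%. Compound 3 differs from compound 1 by (4-fluorophenyl)carbonyl in place of 2-hydroxy-3-phenylpropyl on an amine nitrogen in a ring, and the step is no change at the digits printed from compound 1 to compound 3 (within the scatter). Compound 2, in this assay, gives 100%, level with both others within the scatter. The difference between the cores of compound 1 and compound 2 is not broken down here.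

Compound 4 `O=C(c1ccc(F)cc1)N1CCC(NCC[S+]([O-])C(c2ccc(F)cc2)c2ccc(F)cc2)CC1` has not been measured. It differs from compound 2 by (4-fluorophenyl)carbonyl in place of 2-hydroxy-3-phenylpropyl on an amine nitrogen in a ring, the same change as from compound 1 to compound 3, made at the same place. Because the earlier step was no change at the digits printed from compound 1 to compound 3 (within the scatter), a step of the same size, a number 2 percentage points lower from compound 2 to compound 4 (within the scatter), is expected in this assay. Compound 4 is thus estimated at 98%, between 85% and 100%.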

Compound 4, percent of the compound remaining: 100%
Compound 4: middle estimate off by 2 percentage points, on the low side, and the stated range covers the measured number.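

In this assay, placing (4-fluorophenyl)carbonyl in place of 2-hydroxy-3-phenylpropyl gives no change at the digits printed from compound 2 to compound 4 (within the scatter), and the two cores agree: the same change on two cores in this assay, no change at the digits printed (within the scatter) from compound 1 to compound 3 and no change at the digits printed (within the scatter) from compound 2 to compound 4, 0 percentage points apart, within the scatter of two such steps This shows that the change leaves the read-out unmoved on both cores shown. It does not show that the same would hold on a core that gives a lower number, as all four compounds read the same value and two cores are a narrow base.

The compounds shown leave open what an acetyl group or a longer chain ending in a carboxylic acid would give on the same ring nitrogen. They also leave open whether any group at this place can move this read-out at all.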